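Trading dibromophenyl for chlorodifluorophenyl on the sulfonamide

This account rests on a few compounds, and the source may have more. Where it says the series, first, only, none or still open, it means among the compounds named here.

Going by the values given here, compound 1 `COc1ccc(S(=O)(=O)Nc2cc(Br)cc(Br)c2)cc1N1CCNCC1` is one of two compounds measured in an assay on isolated protein for binding affinity to 5-hydroxytryptamine receptor 6 (Homo sapiens) (on this read-out higher numbers stand for weaker inhibition and lower numbers for stronger inhibition), where compound 1 gives 0.501 nM, the lower of the two numbers and therefore the stronger binder. Compound 2 `COc1ccc(S(=O)(=O)Nc2cc(Br)cc(Cl)c2Br)cc1N1CCNCC1` differs from it only in the aryl group on the sulfonamide nitrogen, and in this assay compound 2 gives 3.98 nM; the change a 7.9-fold higher number from compound 1 to compound 2 (0.90 log units; beyond the scatter).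

Compound 3 `COc1ccc(S(=O)(=O)Nc2cc(F)cc(F)c2Cl)cc1N1CCNCC1` carries a third aryl group in the same place, differing from compound 1 as follows: 2-chloro-3,5-difluorophenyl in place of 3,5-dibromophenyl on a sulfonamide nitrogen. Like the change to compound 2, this both alters the halogens and adds a third halogen to the ring. Among the compounds with values here, the only comparison available, the step from compound 1 to compound 2, weakened binding by a modest amount, so a loss of similar order is expected here, although swapping both bromines for fluorines has no direct precedent among the measured compounds and widens the uncertainty. The expected change is a 6.0-fold higher number from compound 1 to compound 3 (0.78 log units; beyond the scatter). On this basis compound 3 is estimated at 3 nM, within a range of 0.8 nM to 12 nM.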

Compound 3, inhibition constant: 31.6 nM
The estimate for compound 3 lay 11-fold (1.02 log units) below the measured number; the measured number lies above the stated range.
By their numbers in this assay, from the lowest: compound 1; then compound 2; then compound 3.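

In this assay the aryl group on the sulfonamide nitrogen proves far more sensitive than the earlier pair suggested: replacing 3,5-dibromophenyl with 2-chloro-3,5-difluorophenyl gives a 63-fold higher number from compound 1 to compound 3 (1.80 log units; beyond the scatter) in a single change. Compound 3 also stands apart from the other ring with three halogens, with a 7.9-fold higher number from compound 2 to compound 3 (0.90 log units; beyond the scatter) on the same read-out, so the number of halogens alone does not set the result, and the identity of the halogens goes with a clear difference among these three compounds. Nothing available explains why the halogens order the compounds in this way.

Because the step to compound 3 removes both bromines and brings in chlorine and fluorine together, the share of each halogen in the weaker binding stays unresolved, and 3,5-difluorophenyl or 3,5-dichlorophenyl on the sulfonamide nitrogen would help to separate them. On these data alone, it also remains open how this position would respond to groups other than halogens, such as an amine or a carboxylic acid on the ring.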